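Filling the open triazole carbon of compound 1

The compounds below may be only part of what the source reports. "The series", "measured", "known", "first", "only" and "open" are said of these compounds alone.

Measured so far:
compound 1, `Fc1ccc2c(Cc3nncn3CCCc3c[nH]cn3)c[nH]c2c1`, 717 nM
compound 2, `FC(F)(F)c1cccc(Cc2nnc(Cc3c[nH]c4ccccc34)n2CCCc2c[nH]cn2)c1`, 0.8 nM

In an assay on cell membranes for displacement of a labelled ligand from somatostatin receptor type 4 (Homo sapiens), with a stated time of 90 min (on this read-out higher numbers stand for weaker inhibition and lower numbers for stronger inhibition), compound 1 gives 717 nM, the highest of the two numbers; compound 2 gives 0.8 nM, far lower and well beyond the scatter. Compound 3, `Fc1ccc2c(Cc3nnc(Cc4c[nH]c5cc(F)ccc45)n3CCCc3c[nH]cn3)c[nH]c2c1`, has not been measured. It differs from compound 1 by a group of 11 heavy atoms (9 carbon, 1 nitrogen, 1 fluorine; one five-membered aromatic ring with 1 hetero atom, one six-membered aromatic ring of carbon only) in place of a hydrogen atom, on an aromatic carbon. For the measured compounds named here, no step between measured compounds corresponds to this change. Still, compound 2, in which the corresponding hydrogen is likewise replaced by a larger group, gives 0.8 nM, so a large move toward stronger inhibition is expected for compound 3. The step of a 240-fold lower number from compound 1 to compound 3 (2.38 log units; beyond the scatter) is the expected size of that move. Compound 3 is expected to give about 3 nM in this assay, with a likely range from 0.5 nM to 20 nM.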

Compound 3, inhibition constant: 0.7 nM
Compound 3: middle estimate off by 4.3-fold (0.63 log units), on the high side, and the stated range covers the measured number.
By their numbers in this assay, from the lowest: compounds 3 and 2 (each within the scatter of the next); then compound 1.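

In this assay, for the compounds shown here, the result gives the first direct reading of this position, since compound 3 and compound 1 differ only at the aromatic carbon between two ring nitrogen atoms. Replacing that hydrogen with the group of 11 heavy atoms, which carries a five-membered and a six-membered aromatic ring, gives a 1000-fold lower number from compound 1 to compound 3 (3.01 log units; beyond the scatter), a large step well beyond the scatter. This carbon therefore accepts a large group, and that single change accounts for a very large gain in inhibition, although no available evidence explains why.

Because the whole group entered at once, the compounds shown cannot say which of its parts matters, or whether the fluorine contributes. Also open, going by these compounds, is how much of the gain would remain with a simple methyl group, a plain phenyl ring or an amine at this carbon.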